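A Methoxyphenyl Swap Against Two Matching Values

A few compounds are considered here, and "the series" means these few. Any claim that something is new, unique, unknown or untested is made for them only; others in the source may bear on it.

In a functional assay on HT-1080 cells (Homo sapiens) for cytotoxicity, read by MTT assay, with a stated time of 72 h (on this read-out lower numbers stand for stronger inhibition and higher numbers for weaker inhibition), compound 1 (`COc1cccc(/C=C2\CCC/C(=C\c3cccc(O)c3)C2=O)c1OC`) gives 8500 nM and compound 2 (`COc1ccc(/C=C2\CCC/C(=C\c3ccccc3Br)C2=O)cc1OC`) gives 8400 nM. These values lie within the scatter of each other, so compound 2 stands level with compound 1. Compound 3 (`COc1cccc(/C=C2\CCC/C(=C\c3ccc(OC)c(OC)c3)C2=O)c1`) carries 3-methoxyphenyl in place of 2-bromophenyl on a double-bonded chain carbon bound to a double-bonded ring carbon. Among the compounds with values here, no step between measured compounds is available to guide the expectation. In this assay, the expected change is a 1.2-fold lower number from compound 2 to compound 3 (0.08 log units; within the scatter), with no step beyond the scatter anticipated. The estimated value for compound 3 is 7000 nM, with an expected range of 2000 nM to 22000 nM.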

Compound 3, half-maximal inhibitory concentration: 4600 nM
Estimate against measurement, compound 3: 1.5-fold (0.18 log units) above; low and high end bracket the measured number.
By their numbers in this assay, from the lowest: compounds 3, 2 and 1 (each within the scatter of the next).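

In this assay, the swap shows a 1.8-fold lower number from compound 2 to compound 3 (0.26 log units; within the scatter), so 3-methoxyphenyl and 2-bromophenyl stand level on a double-bonded chain carbon bound to a double-bonded ring carbon. Within the data shown here, this is the only step read at this position, and it shows that this exchange of groups leaves the number within the scatter. No evidence bearing on this result is available.

As far as these compounds go, whether an amine or a carboxylic acid on the phenyl ring at this position would carry the number beyond the scatter remains open.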